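Aromatic methyl substitution across two amide cores

A few compounds are considered here, and "the series" means these few. Any claim that something is new, unique, unknown or untested is made for them only; others in the source may bear on it.

Measured in a functional assay on the whole organism for agonist activity, with Mus musculus as the target; on this read-out higher numbers stand for an effect only at larger amounts of compound and lower numbers for an effect already at smaller amounts:
compound 1 `CC(=O)N(C)CC#CCn1ccnc1`: 1.4 mg/kg
compound 2 `CC(=O)N(C)CC#CCn1cncc1C`: > 100 mg/kg, a limit of the assay
compound 3 `CCOC(=O)N(C)C(C)C#CCn1ccnc1`: > 100 mg/kg, a limit of the assay

Among the measured compounds shown here, the one counted step within the measured set is methyl in place of hydrogen on an aromatic carbon. On this assay it reads an at least 71-fold higher number from compound 1 to compound 2 (1.85 log units; beyond the scatter), and the value of compound 2 is a limit, so the true size of the step is not known beyond that. Relevant here is the limit of > 100 mg/kg in this assay, at which 2 of the 3 values shown sit.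

Compound 4 `CCOC(=O)N(C)C(C)C#CCn1cncc1C` is not yet measured. It stands to compound 3 as compound 2 stands to compound 1: methyl in place of hydrogen on an aromatic carbon. The two place descriptions agree except that in compound 1 the neighbouring ring atom bears a group of 9 heavy atoms, whereas in compound 3 it bears a large group; the change is the same kind of change, not the same. The difference between the two cores is not broken down here.

The expectation for compound 4 rests on two things: compound 3 already gives only a limit, > 100 mg/kg, and the same kind of change in the other core gave an at least 71-fold higher number from compound 1 to compound 2 (1.85 log units; beyond the scatter). Compound 4 is therefore expected to sit beyond the limit, with an estimated step that the limit leaves unreadable from compound 3 to compound 4. The estimate for compound 4 is 300 mg/kg, with a plausible range from 100 mg/kg to 3000 mg/kg; the assay is most likely to report only a limit.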

Compound 4, dose for half-maximal effect: > 100 mg/kg
Compound 4: only a limit was reported; the forecaster's own chance of this, stated with the estimate: 90%; the middle value is on the limit's open side.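

No step can be read from compound 3 to compound 4 because both compounds sit at the same limit of the assay, so the effect of methyl in place of hydrogen on an aromatic carbon stays unreadable in this core: the limit of > 100 mg/kg in this assay, at which 3 of the 4 values shown sit. The compounds shown leave open how far beyond that limit compound 3 and compound 4 each lie, and whether they differ at all.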